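The source may report more compounds than this note shows. Statements on the series, on what has been measured and on what is new or still open speak of the compounds shown alone.

Measured compounds in a functional assay on the whole organism with Rattus norvegicus as the target, in the maximal electroshock model; on this read-out higher numbers stand for an effect only at larger amounts of compound and lower numbers for an effect already at smaller amounts:

- compound 1 `CNc1nccn2c(Cc3cccc(F)c3)nnc12`: 4 mg/kg
- compound 2 `Nc1nccn2c(Cc3cccc(F)c3)nnc12`: the value > 25 mg/kg is a limit of the assay, not a number
- compound 3 `CNc1nccn2c(Cc3ccc(F)cc3)nnc12`: 25 mg/kg

Going by the values given here, the one measured step is an at least 6.2-fold higher number from compound 1 to compound 2 (0.79 log units; beyond the scatter); the change there is hydrogen in place of methyl on a nitrogen on an aromatic ring. Its size is bounded on one side only because of the limit of > 25 mg/kg in this assay, at which 1 of the 3 values shown sits, so the true step may be larger than the stated number.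

Compound 3 carries the same atoms as compound 1 joined differently; the difference between the two cores is not broken down here. Their two values show compound 3 sitting at the higher number, beyond the scatter of this assay.

Compound 4 `Nc1nccn2c(Cc3ccc(F)cc3)nnc12` is not yet measured. It differs from compound 3 by hydrogen in place of methyl on a nitrogen on an aromatic ring, the same change, at the same place, as from compound 1 to compound 2. The expectation for compound 4 rests on compound 1 and compound 2, where this change gave an at least 6.2-fold higher number from compound 1 to compound 2 (0.79 log units; beyond the scatter), and on compound 3 starting already at 25 mg/kg. A step of similar size is expected, a 4.8-fold higher number from compound 3 to compound 4 (0.68 log units; beyond the scatter). Compound 4 is therefore estimated at 120 mg/kg, in the range 40 mg/kg to 400 mg/kg, with a strong chance that this assay reports only a limit rather than a number.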

Compound 4, dose for half-maximal effect: > 25 mg/kg
Compound 4: a limit, no number; the forecaster's own chance of this, stated with the estimate: 75%; the middle value is on the limit's open side.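

In this assay compound 4 gives > 25 mg/kg, which is a limit of the assay and not a number. The step reads a number no lower from compound 3 to compound 4 (the limit leaves the size open) and no more can be said of its size. The change from methylamino to amino does not bring the number down on either core, so its direction, as far as it can be read, carries over from the core of compound 1 to the core of compound 3, and the two steps stand as follows: the same change on two cores in this assay, an at least 6.2-fold higher number (0.79 log units; beyond the scatter) from compound 1 to compound 2 and a number no lower (the limit leaves the size open) from compound 3 to compound 4; the limit leaves it open whether they differ This does not show that the change costs the same on both cores, nor does it give any size for the second step, which cannot be read because both amino compounds stop at the same bound: the limit of > 25 mg/kg in this assay, at which 2 of the 4 values shown sit.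

The compounds shown leave open how far the number rises on loss of the methyl, and whether an ethyl group, a longer chain or a second methyl on the same nitrogen would keep the effect that compound 1 shows at 4 mg/kg in this assay. They also leave open whether a chlorine atom or a methoxy group in place of the fluorine would change the result for the methylamino and amino pairs.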